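Swapping the Side Chain: From Hydroxy to Methylsulfanyl

The compounds below may be only part of what the source reports. "The series", "measured", "known", "first", "only" and "open" are said of these compounds alone.

The measured compounds and their values:
- Compound 1, `O=C(CN(c1nc(Cl)nc2[nH]cnc12)C1CC1)N[C@@H](CO)C(=O)OCc1ccccc1`: 31.9%
- Compound 2, `O=C(CN(c1nc(Cl)nc2[nH]cnc12)C1CC1)N[C@@H](CO)C(=O)O`: 38.7%
- Compound 3, `CC[C@H](C)[C@H](NC(=O)CN(c1ncnc2c1ncn2C1CCCCO1)C1CC1)C(=O)OCc1ccccc1`: 25.6%

In a functional assay on the whole organism (Tail, strain ICR) with Mus musculus as the target, in the tail flick test, with a stated time of 30 min, at a dose of 25 umol/kg by the oral route (on this read-out higher numbers stand for a stronger effect at the one dose given and lower numbers for a weaker effect), compound 1 gives 31.9%, the second highest of the three numbers. Its nearest neighbour is compound 3, and its furthest is compound 2, yet both gaps lie within the scatter, so the three compounds cannot be told apart on these numbers.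

The new compound 4, `CSCC[C@H](NC(=O)CN(c1nc(Cl)nc2[nH]cnc12)C1CC1)C(=O)OCc1ccccc1`, differs from compound 1 in one place: (methylsulfanyl)methyl in place of hydroxy on a saturated chain carbon, two bonds along the chain from an amide-type nitrogen and a carbonyl carbon. Within the data shown here, no measured step changes this part of the molecule. Among the measured compounds shown here, the only measured step, a number 6.8 percentage points higher from compound 1 to compound 2 (within the scatter), alters the ester end instead and stays within the scatter, so it says nothing about the side chain. Compound 3 carries a different core and a different side chain, so its value can only be set beside that of compound 1 as two numbers that happen to lie close.

With nothing bearing on the change, compound 4 is expected to show no step beyond the scatter, a number 1.9 percentage points lower from compound 1 to compound 4 (within the scatter). Compound 4 is therefore estimated at 30%, within 14% to 46%.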

Compound 4, a percentage reported as activity, at one dose (the size of the read-out at that dose, not a potency): 22.2%
Beside the measured number, compound 4's estimate is 7.8 percentage points above it; the measured number falls inside the stated range.
By their numbers in this assay, from the lowest: compounds 4, 3, 1 and 2 (each within the scatter of the next, the first and the last beyond it).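

Among these compounds, this is the first measured step at this side-chain position: in this assay, the change gives a number 9.7 percentage points lower from compound 1 to compound 4 (within the scatter). Replacing hydroxy with (methylsulfanyl)methyl therefore exchanges a group with 1 hydrogen-bond donor for a larger one with 0 without a shift beyond the usual scatter, so neither the donor count nor the added heavy atoms show a clear effect on the read-out in this single pair. No available measurement explains the step.

As far as these compounds go, it remains open whether an amine or a longer chain at this carbon would produce a step beyond the scatter. It is also unknown whether the (methylsulfanyl)methyl change would give a similar result in the free-acid series of compound 2, where the benzyl ester is absent.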